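The source may hold more compounds than are shown below. What is called first, only, known or untested is meant among the compounds shown, and "the series" means these compounds.

Measured in an in vitro ADME assay on microsomes from liver (Homo sapiens) for metabolic stability, read by LC-MS; on this read-out higher numbers stand for a longer-lived compound and lower numbers for a shorter-lived compound:
- compound 1 `CON/C(=N\C1=NC(=O)C(=O)N1C(C)C)Nc1ccc(Cl)c(Cl)c1`: > 1 h, a limit
- compound 2 `CC(C)N1C(=O)C(=O)N=C1/N=C(\NCCN1CCCC1)Nc1ccc(Cl)c(Cl)c1`: 0.886 h

Among the compounds with values here, compound 2 holds the only number so far. Compound 1 sits at a limit: the limit of > 1 h in this assay, at which 1 of the 2 values shown sits.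

Compound 3 `CC(C)N1C(=O)C(=O)N=C1/N=C(\NCCCCN1CCCC1)Nc1ccc(Cl)c(Cl)c1` differs from compound 2 thus: 2-(pyrrolidin-1-yl)ethyl in place of pyrrolidin-1-yl on a saturated chain carbon, two bonds along the chain from an amine nitrogen. Within the data shown here, the one measured step that bears on this is an at least 1.1-fold lower number from compound 1 to compound 2 (0.05 log units; that floor lies within the scatter), which brought in 2-(pyrrolidin-1-yl)ethyl in place of methoxy on an amine nitrogen. Its floor lies within the scatter, so no change beyond the scatter is expected in this assay. The expected step is a 1.1-fold lower number from compound 2 to compound 3 (0.04 log units; within the scatter). Compound 3 is estimated at 0.8 h, with an expected range of 0.4 h to 1.5 h.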

Compound 3, half-life: > 1 h
Compound 3: no number, only a limit (the forecaster's own chance of this, stated with the estimate: 25%); middle value at least 1.2-fold (0.09 log units) away from the limit.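

In this assay, going from (2-(pyrrolidin-1-yl)ethyl)amino to (4-(pyrrolidin-1-yl)butyl)amino gives an at least 1.1-fold higher number from compound 2 to compound 3 (0.05 log units; that floor lies within the scatter). The longer chain at this place therefore shows no shorter half-life than the 2-(pyrrolidin-1-yl)ethyl chain of compound 2. Compound 3 gives a limit and not a number, the second in the series: the limit of > 1 h in this assay, at which 2 of the 3 values shown sit.

The true size of the step from compound 2 to compound 3 and the steps between the two limits cannot be read. On these data alone, whether a dimethylamino group or a morpholine in place of the pyrrolidine on the butyl chain holds the half-life at this limit stays open.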